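Swapping a sulfonamide for an amide on compound 1

The source may hold more compounds than are shown below. What is called first, only, known or untested is meant among the compounds shown, and "the series" means these compounds.

Compound 1 `CNS(=O)(=O)c1ccc(-c2cnc(N)c(-c3ccc(OC)nc3)c2)cc1`: 9.6 mL.min-1.g-1
Compound 2 `COc1ccc(-c2cc(-c3ccc(S(N)(=O)=O)cc3)cnc2N)cn1`: < 7 mL.min-1.g-1
Compound 3 `COc1ccc(-c2cc(-c3ccc(S(C)(=O)=O)cc3C(F)(F)F)cnc2N)cn1`: < 7 mL.min-1.g-1

Going by the values given here, in an in vitro ADME assay on microsomes from liver (Homo sapiens) for metabolic stability (on this read-out higher numbers stand for fast clearance and lower numbers for slow clearance), compound 1 gives 9.6 mL.min-1.g-1, the only value in this set that is a number rather than a limit. Compound 2 returns only a limit of this assay, < 7 mL.min-1.g-1. Compound 3 likewise returns only a limit, < 7 mL.min-1.g-1; this is the situation described by the limit of < 7 mL.min-1.g-1 in this assay, at which 2 of the 3 values shown sit. Among the compounds with values here, the one step that can be sized is an at least 1.3-fold lower number from compound 1 to compound 2 (0.13 log units; that floor lies within the scatter), and its floor lies within the scatter.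

Compound 4 `CNC(=O)c1ccc(-c2cnc(N)c(-c3ccc(OC)nc3)c2)cc1` differs from compound 1 as follows: methylcarbamoyl in place of methylsulfamoyl on an aromatic carbon. Within the data shown here, no measured step in this set touches the methylcarbamoyl or the methylsulfamoyl in that way, so none bears directly on it, and the single sized step from compound 1 to compound 2 is itself only a floor within the scatter. The expectation is therefore a step no larger than the scatter, with no direction: compound 4 is expected to give about 9 mL.min-1.g-1 in this assay, within 4.5 mL.min-1.g-1 to 18 mL.min-1.g-1. That expected step is a 1.1-fold lower number from compound 1 to compound 4 (0.03 log units; within the scatter).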

Compound 4, intrinsic clearance in microsomes in the Homo sapiens assay: < 7 mL.min-1.g-1
Compound 4: no number, only a limit (the forecaster's own chance of this, stated with the estimate: 30%); at least 1.2-fold (0.10 log units) between middle value and limit.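

Replacing methylsulfamoyl with methylcarbamoyl at this position gives, in the Homo sapiens assay, an at least 1.3-fold lower number from compound 1 to compound 4 (0.13 log units; that floor lies within the scatter), so this printed floor alone does not establish a real difference in clearance, but an amide here reaches the same assay limit as the sulfur-bearing compounds 2 and 3. In a physicochemical assay for lipophilicity, at pH 7.4 (a lower number here means a more polar compound, a higher number a more lipophilic compound), compound 1 gives 2.2 and compound 4 gives 1.8. In the physicochemical assay, the same change gives the first measured difference at this position, with the methylcarbamoyl compound the more polar: the measured distribution coefficient of compound 1, 2.2, and of compound 4, 1.8, a number 0.40 log units lower (beyond the scatter) Compound 4 returns only a limit, as does compound 2, and the step between them cannot be read: the limit of < 7 mL.min-1.g-1 in the Homo sapiens assay, at which 3 of the 4 values shown sit.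

As far as these compounds go, how far the clearance of compound 4 lies under its limit remains open. So does whether a carboxylic acid or an amide with a longer chain on its nitrogen would also stay at that limit at this position.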